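Exchanging the acyl aryl group of compound 3

A few compounds are considered here, and "the series" means these few. Any claim that something is new, unique, unknown or untested is made for them only; others in the source may bear on it.

In a functional assay on A549 cells (Homo sapiens) for inhibition, read by MTT assay, with a stated time of 72 h (a lower number here means a stronger inhibitor, a higher number a weaker inhibitor), compound 3 `CN(C(=O)NC(=O)c1ccc(C(F)(F)F)cc1)c1nc(C(F)(F)F)c(C(=O)N/N=C/c2cc(C(F)(F)F)cc(C(F)(F)F)c2)s1` gives 5.9 ug/mL. Its nearest neighbour among the measured compounds is compound 2 `CN(C(=O)NC(=O)c1ccc(F)c(F)c1)c1nc(C(F)(F)F)c(C(=O)N/N=C/c2cc(C(F)(F)F)cc(C(F)(F)F)c2)s1`, at 5.47 ug/mL, a gap within the usual scatter; furthest away is compound 1 `CN(C(=O)NC(=O)c1c(F)cccc1F)c1nc(C(F)(F)F)c(C(=O)N/N=C/c2cccc(C(F)(F)F)c2)s1`, at 27.6 ug/mL, a gap beyond it. Compound 4 `CN(C(=O)NC(=O)c1c(F)cccc1F)c1nc(C(F)(F)F)c(C(=O)N/N=C/c2cc(C(F)(F)F)cc(C(F)(F)F)c2)s1` has not yet been measured and differs from compound 3 by 2,6-difluorophenyl in place of 4-(trifluoromethyl)phenyl on a carbonyl carbon. Going by the values given here, one measured step touches the same position: a 1.1-fold higher number from compound 2 to compound 3 (0.03 log units; within the scatter), which stayed within the scatter. Among the compounds with values here, no measured step pairs the entering group with the leaving group directly, and compound 1 carries the entering group on a differently substituted hydrazone partner, so its number cannot be assigned to either part. The step is therefore expected to be modest, a 1.5-fold higher number from compound 3 to compound 4 (0.18 log units; within the scatter). Compound 4 is expected to give about 9 ug/mL, between 4 ug/mL and 25 ug/mL.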

Compound 4, half-maximal inhibitory concentration: 17.3 ug/mL
For compound 4 the middle estimate is 1.9-fold (0.28 log units) below the measured one, and the stated range covers the measured number.
By their numbers in this assay, from the lowest: compounds 2 and 3 (each within the scatter of the next); then compounds 4 and 1 (each within the scatter of the next).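

In this assay the acyl aryl position proves sensitive after all: a 2.9-fold higher number from compound 3 to compound 4 (0.47 log units; beyond the scatter) and a 3.2-fold higher number from compound 2 to compound 4 (0.50 log units; beyond the scatter), both beyond the scatter, whereas the earlier exchange on this carbonyl carbon stayed within it. Trifluoromethyl in place of hydrogen on an aromatic carbon of the hydrazone partner gives a 1.6-fold lower number from compound 1 to compound 4 (0.20 log units; within the scatter), within the scatter, so this second change does not separate the two 2,6-difluorophenyl compounds. No evidence is available on what lies behind these steps. From the compounds shown here alone, whether a single fluorine on the phenyl ring would read like 2,6-difluorophenyl remains open. So does how an aminophenyl or carboxyphenyl group would read at this carbonyl carbon.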